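The source may report more compounds than this note shows. Statements on the series, on what has been measured and on what is new or still open speak of the compounds shown alone.

Measured so far:
compound 1 `CCCCCCC(=O)CC/C=C/C=C/C(=O)NCC(C)C`: 15.6%
compound 2 `CC/C=C/C/C=C\CC/C=C/C=C/C(=O)NCC(C)(C)O`: 4%

In a functional assay on cells (Platelet, Oryctolagus cuniculus) for inhibition, read by turbidimetry, with a stated time of 3 min, tested at 20 ug/mL (on this read-out lower numbers stand for a stronger effect and higher numbers for a weaker effect at the one concentration tested), compound 2 gives 4%, the lowest of the two numbers. Compound 1 gives 15.6%, a number beyond the scatter above that of compound 2. Compound 3 `CC/C=C\C/C=C\CC/C=C/C=C/C(=O)NCC(C)(C)O` is not yet measured. Its difference from compound 2: the two compounds have the same atoms and bonds and differ only in configuration as drawn: 1 of 4 stereo elements differ; a double bond is drawn E in compound 2 and Z in compound 3. For the measured compounds named here, no measured pair shows a change of this kind, so the expected step is a number 4 percentage points higher from compound 2 to compound 3 (within the scatter), with no direction anticipated beyond the scatter. Compound 3 is therefore estimated at 8%, within a range of 0% to 25%.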

Compound 3, a percentage reported as activity, at one concentration (the size of the read-out at that concentration, not a potency): 4%
Compound 3: middle estimate off by 4 percentage points, on the high side; the range from low to high includes it.
By their numbers in this assay, from the lowest: compounds 2 and 3 (each within the scatter of the next); then compound 1.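

In this assay, drawing this one double bond Z instead of E gives no change at the digits printed from compound 2 to compound 3 (within the scatter). For the compounds shown here, this is the first pair to isolate a single change: the fact that compounds 2 and 3 differ only in the configuration as drawn. Going by these compounds alone, at the one concentration tested, the read-out therefore does not separate the two drawn forms of this double bond, although a single-concentration read-out gives no potency for either compound.

Going by these compounds, whether the other double bonds tolerate the same change remains open. Also open, on these data alone, is how a carboxylic acid or an amine would read in place of the amide.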